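A few compounds are considered here, and "the series" means these few. Any claim that something is new, unique, unknown or untested is made for them only; others in the source may bear on it.

Working notes on the dithiocarbamate chalcone series.

Among the measured compounds shown here, compound 1 `CN1CCN(C(=S)SCCCOc2ccc(C(=O)/C=C/c3ccc(Cl)cc3)cc2)CC1` is measured in a functional assay on SK-N-SH cells (Homo sapiens) for inhibition, read by MTT assay, with a stated time of 72 h (a higher number here means a weaker inhibitor, a lower number a stronger inhibitor), at 31900 nM, the highest of the two numbers known so far. For the measured compounds named here, the only neighbour is compound 2 `CN1CCN(C(=S)SCCCOc2ccc(C(=O)/C=C/c3cc(Cl)cc(Cl)c3)cc2)CC1`, which in this assay gives 24600 nM; the step of a 1.3-fold lower number from compound 1 to compound 2 (0.11 log units; within the scatter) changes the halogen pattern on the phenyl end of the chain and is within the scatter.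

Compound 3 `O=C(/C=C/c1ccc(Cl)cc1)c1ccc(OCCCSC(=S)N2CCCCC2)cc1` is not yet measured. It differs from compound 1 at the other end of the molecule: piperidin-1-yl in place of 4-methylpiperazin-1-yl on a thiocarbonyl carbon. Going by the values given here, no measured step touches the thiocarbonyl carbon, so the one known step offers no direct read on this change. Among the compounds with values here, with the single measured step already within the scatter, the expectation is a step of no real size, a 1.1-fold lower number from compound 1 to compound 3 (0.03 log units; within the scatter), in this assay.

Compound 3 is therefore estimated at 30000 nM in this assay, with a range from 10000 nM to 90000 nM.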

Compound 3, half-maximal inhibitory concentration: 32200 nM
Beside the measured number, compound 3's estimate is 1.1-fold (0.03 log units) below it; measured number inside the range.
By their numbers in this assay, from the lowest: compounds 2, 1 and 3 (each within the scatter of the next).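

At the thiocarbonyl carbon, the first measured step is a 1.0-fold higher number from compound 1 to compound 3 (0.00 log units; within the scatter) in this assay, so piperidin-1-yl and 4-methylpiperazin-1-yl cannot be told apart here, and the ring's second nitrogen with its methyl group makes no visible difference to the number. This position now matches the phenyl end of the chain, where the step is a 1.3-fold lower number from compound 1 to compound 2 (0.11 log units; within the scatter), so neither of the two places touched has yet given a step beyond the scatter. No measurement to hand offers an explanation for this result.

From the compounds shown here alone, it remains open whether morpholin-4-yl or an open-chain diethylamino group on the thiocarbonyl carbon would move the number beyond the scatter. Going by these compounds, it is also open whether a longer chain would do so, and whether this result holds in other cell lines.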